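Chain lengthening: the same kind of change in two pairs

The compounds below may be only part of what the source reports. "The series", "measured", "known", "first", "only" and "open" are said of these compounds alone.

Compound 1 `C#Cc1cccc(Nc2ncnc3cc(OCCCCn4ccnc4[N+](=O)[O-])c(OC)cc23)c1` in a functional assay on HT-29 cells (Homo sapiens) for inhibition, read by sulforhodamine B assay, with a stated time of 72 h (a higher number here means a weaker inhibitor, a lower number a stronger inhibitor), gives 2520 nM. Compound 2 `C#Cc1cccc(Nc2ncnc3cc(OCCCCCn4ccnc4[N+](=O)[O-])c(OC)cc23)c1` carries the change (2-nitro-1H-imidazol-1-yl)methyl in place of 2-nitro-1H-imidazol-1-yl on a saturated chain carbon, four bonds along the chain from an oxygen on an aromatic ring and gives 1310 nM; the step is a 1.9-fold lower number from compound 1 to compound 2 (0.28 log units; within the scatter). Compound 3 `COc1cc2c(Nc3cccc(Br)c3)ncnc2cc1OCCCCCn1ccnc1[N+](=O)[O-]` gives 5050 nM; the step of a 3.9-fold higher number from compound 2 to compound 3 (0.59 log units; beyond the scatter) is beyond the scatter. The difference between the cores of compound 1 and compound 3 is not broken down here. Compound 4 `COc1cc2c(Nc3cccc(Br)c3)ncnc2cc1OCCCCCCn1ccnc1[N+](=O)[O-]`, not yet measured, differs from compound 3 by (2-nitro-1H-imidazol-1-yl)methyl in place of 2-nitro-1H-imidazol-1-yl on a saturated chain carbon, five bonds along the chain from an oxygen on an aromatic ring. For the measured compounds named here, this is the same kind of change as the one between compound 1 and compound 2, not the same: there the place is on a saturated chain carbon, four bonds along the chain from an oxygen on an aromatic ring, here it is five bonds along the chain from an oxygen on an aromatic ring. Going by the values given here, for compound 4 the expected step in this assay is a 1.6-fold lower number from compound 3 to compound 4 (0.20 log units; within the scatter), set beside the earlier one, because the matching change gave a 1.9-fold lower number from compound 1 to compound 2 (0.28 log units; within the scatter) and that single pair is the only precedent. Compound 4 is thus estimated at 3200 nM, with a range from 1300 nM to 8000 nM.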

Compound 4, half-maximal inhibitory concentration: 10500 nM
Estimate against measurement, compound 4: 3.3-fold (0.52 log units) below; the measured number lies above the stated range.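

In this assay, the change on the core of compound 3 gives a 2.1-fold higher number from compound 3 to compound 4 (0.32 log units; beyond the scatter), so the result seen on the core of compound 1 is not repeated here. The two steps point in opposite directions and do not agree: the same change on two cores in this assay, a 1.9-fold lower number (0.28 log units; within the scatter) from compound 1 to compound 2 and a 2.1-fold higher number (0.32 log units; beyond the scatter) from compound 3 to compound 4, 4.0-fold (0.60 log units) apart, beyond the scatter of two such steps This shows that, in these two pairs, the effect of lengthening the chain does not carry over unchanged from one core to the other, but it does not show that the core alone decides the outcome, since the pairs differ both in ethynyl against bromo and in the place of the change, four against five bonds along the chain from an oxygen on an aromatic ring.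

The compounds shown leave open how the chain of compound 4 behaves on the core of compound 1, and how the chain of compound 1 behaves on the core of compound 3, either of which would separate the core from the place of the change. They also leave open whether a longer chain, or an amine in place of the 2-nitro-1H-imidazol-1-yl group, would follow either trend.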